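Swapping Methylphenyl for Difluorophenyl on a Shared Core

The compounds below may be only part of what the source reports. "The series", "measured", "known", "first", "only" and "open" are said of these compounds alone.

Of the compounds shown here, two built on the same core have been measured, and they differ only in one outer ring. Compound 1 `COc1ccc(-c2ccnc(C(=O)Nc3ccc(Oc4ccnc5cc(OCCCN6CCN(C)CC6)c(OC)cc45)c(F)c3)c2)cc1` in a functional assay on NCI-H460 cells (Homo sapiens) for cytotoxicity, read by MTT assay, with a stated time of 72 h (on this read-out lower numbers stand for stronger inhibition and higher numbers for weaker inhibition), gives 370 nM. Compound 2 `COc1cc2c(Oc3ccc(NC(=O)c4nccc(-c5ccc(C)cc5)n4)cc3F)ccnc2cc1OCCCN1CCCCC1`, which carries a 4-methylphenyl in that position, gives in this assay a value of 230 nM. These two numbers sit within the usual scatter of each other, so the data do not separate compound 2 from compound 1. Compound 3 `COc1cc2c(Oc3ccc(NC(=O)c4nccc(-c5ccc(F)cc5F)n4)cc3F)ccnc2cc1OCCCN1CCCCC1` has not yet been measured. It differs from compound 2 in one place: 2,4-difluorophenyl in place of 4-methylphenyl on an aromatic carbon. Among the compounds with values here, no measured pair shows the effect of this exact swap, so there is no step to lean on. Since compound 1 and compound 2 already stay close with different rings here, the step of a 1.3-fold higher number from compound 2 to compound 3 (0.12 log units; within the scatter) is expected to remain within the scatter, with no clear direction. Compound 3 is therefore estimated to give 300 nM in this assay, with a likely range from 100 nM to 900 nM.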

Compound 3, half-maximal inhibitory concentration: 550 nM
The estimate for compound 3 lay 1.8-fold (0.26 log units) below the measured number, and the stated range covers the measured number.
By their numbers in this assay, from the lowest: compounds 2, 1 and 3 (each within the scatter of the next, the first and the last beyond it).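

Replacing 4-methylphenyl with 2,4-difluorophenyl on this aromatic carbon gives, in this assay, a 2.4-fold higher number from compound 2 to compound 3 (0.38 log units; beyond the scatter), so the ring at this position can shift the result, if only modestly. Since a higher number means weaker inhibition, compound 2 is the stronger of this pair. Nothing measured here explains why the number moves with this swap.

This single change removes the methyl and adds two fluorines at once, so the compounds shown cannot tell which of these matters; a plain phenyl ring or a ring with a single fluorine would be needed to separate them. From the compounds shown here alone, it also remains open how this position would respond to a ring carrying an amine or a carboxylic acid.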